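Aryl swap on the triazole nitrogen of the sulfonamide series

The compounds below may be only part of what the source reports. "The series", "measured", "known", "first", "only" and "open" are said of these compounds alone.

Two members of the series have been measured: compound 1 `Cc1ccc(-n2cc(-c3ccccc3NS(=O)(=O)c3c[nH]c(=O)[nH]c3=O)nn2)cc1` and compound 2 `O=c1[nH]cc(S(=O)(=O)Nc2ccc(-c3cn(-c4ccccc4F)nn3)cc2)c(=O)[nH]1`. In a functional assay on A549 cells (Homo sapiens) for antiproliferative activity, read by MTT assay, with a stated time of 24 h (a higher number here means a weaker inhibitor, a lower number a stronger inhibitor), compound 1 gives 2910 nM. In this assay compound 2 gives 5960 nM, the higher of the two numbers; the gap to compound 1 lies beyond the usual scatter. The two differ in more than one place, so no single change is tied to that gap.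

Compound 3 `O=c1[nH]cc(S(=O)(=O)Nc2ccc(-c3cn(-c4ccc(Cl)cc4)nn3)cc2)c(=O)[nH]1` is not yet measured. It differs from compound 2 in one place: 4-chlorophenyl in place of 2-fluorophenyl on an aromatic nitrogen. Within the data shown here, no measured pair covers this change. A step of a 1.5-fold lower number from compound 2 to compound 3 (0.17 log units; within the scatter) is expected in this assay, small and toward a lower number, hardly beyond the scatter. Compound 3 is expected to give about 4000 nM, within a range from 1500 nM to 12000 nM.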

Compound 3, half-maximal inhibitory concentration: 1210 nM
Estimate against measurement, compound 3: 3.3-fold (0.52 log units) above, and the stated range ends above it.
By their numbers in this assay, from the lowest: compound 3; then compound 1; then compound 2.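

In this assay, among these compounds, this is the first single-place step: on the aromatic nitrogen of the five-membered ring, 4-chlorophenyl in place of 2-fluorophenyl gives a 4.9-fold lower number from compound 2 to compound 3 (0.69 log units; beyond the scatter). The read-out at this position therefore responds to the aryl substituent, even though the two groups have the same heavy-atom count, and neither has hydrogen-bond donors, hydrogen-bond acceptors or net charge. Both the halogen and its place on the phenyl ring change in this one step, and no measurement of any property bears on the result.

The compounds shown leave open whether the step follows the chlorine, its place on the ring, or both. Also open, going by these compounds, is how an unsubstituted phenyl, an aminophenyl or a carboxyphenyl would read at this nitrogen.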